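Moving the fluorine around the ring on a piperidine side chain

The compounds below may be only part of what the source reports. "The series", "measured", "known", "first", "only" and "open" are said of these compounds alone.

Compound 1 `N#Cc1c(N2CCC(c3ccccc3)CC2)ccn(CC2CC2)c1=O` gives 151 nM in a functional assay on CHO cells for positive allosteric modulation of metabotropic glutamate receptor 2 (Homo sapiens), with a stated time of 30 min; a lower number here means that less compound is needed, a higher number that more compound is needed for the effect.
Compound 2 `N#Cc1c(N2CCC(c3ccccc3F)CC2)ccn(CC2CC2)c1=O` gives 81 nM in this assay.
Compound 3 `N#Cc1c(N2CCC(c3cccc(F)c3)CC2)ccn(CC2CC2)c1=O` gives 141 nM in this assay.

Among these three numbers compound 3 sits second highest: its nearest neighbour is compound 1, and the furthest is compound 2, yet both of those gaps lie within the usual scatter of this assay, so no ordering can be read from them.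

Compound 4 `N#Cc1c(N2CCC(c3ccc(F)cc3)CC2)ccn(CC2CC2)c1=O` has not yet been measured. Its difference from compound 3 is 4-fluorophenyl in place of 3-fluorophenyl on a saturated ring carbon. The same atoms are present; only the position of the fluorine on the aromatic ring has changed.

Among the measured compounds shown here, three measured steps bear on this. Adding a fluorine to the unsubstituted phenyl of compound 1 gave a 1.9-fold lower number from compound 1 to compound 2 (0.27 log units; within the scatter) and a 1.1-fold lower number from compound 1 to compound 3 (0.03 log units; within the scatter), and moving that fluorine from one ring position to another gave a 1.7-fold higher number from compound 2 to compound 3 (0.24 log units; within the scatter). All three lie within the scatter. A further shift of the fluorine is therefore expected to produce no step beyond the scatter in this assay, in either direction.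

On that basis compound 4 is estimated at 120 nM, with a range from 50 nM to 300 nM, meaning an expected step of a 1.2-fold lower number from compound 3 to compound 4 (0.07 log units; within the scatter).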

Compound 4, half-maximal effective concentration: 89 nM
For compound 4 the middle estimate is 1.3-fold (0.13 log units) above the measured one, within the range that was stated.
By their numbers in this assay, from the lowest: compounds 2, 4, 3 and 1 (each within the scatter of the next).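

In this assay the 4-fluorophenyl of compound 4 completes the set of three fluorophenyl groups on the saturated ring carbon: the swap for the 3-fluorophenyl gives a 1.6-fold lower number from compound 3 to compound 4 (0.20 log units; within the scatter) and the swap for the 2-fluorophenyl gives a 1.1-fold higher number from compound 2 to compound 4 (0.04 log units; within the scatter) while adding this fluorine to the plain phenyl gives a 1.7-fold lower number from compound 1 to compound 4 (0.23 log units; within the scatter) and so closes the comparison. Each of these steps lies within the scatter, as did the earlier ones, so the three fluorophenyl groups cannot be told apart from one another or from the plain phenyl, and this series of compounds has no ranking that can be trusted. Nothing measured alongside these numbers speaks to any cause behind them.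

The only substituent shown on this phenyl is a single fluorine, so it remains open whether a chlorine, a methyl or a methoxy group there would give a step beyond the scatter. Also open, on these data alone, is what would happen with two fluorines on the ring, or with a pyridine in place of the phenyl.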